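Aryl swap on a compound at the assay limit

The source may hold more compounds than are shown below. What is called first, only, known or untested is meant among the compounds shown, and "the series" means these compounds.

Series notes on the group carried on the shared core. In a functional assay on HCT-116 cells (Homo sapiens) for antiproliferative activity, read by CellTiter-Glo, with a stated time of 72 h (on this read-out lower numbers stand for stronger inhibition and higher numbers for weaker inhibition), compound 1 (`O=C(NO)c1ccc(/C=C/c2ccnc(-c3ccccc3O)c2)cc1`) gives 1450 nM and compound 2 (`O=C(NO)c1ccc(/C=C/c2ccnc(-c3cccnc3)c2)cc1`) gives 5140 nM. Compound 3 (`O=C(NO)c1ccc(/C=C/c2ccnc(-c3ccc(F)cc3)c2)cc1`) gives > 10000 nM, which is a limit of the assay and not a number.

Compound 4 (`Cc1ccc(-c2cc(/C=C/c3ccc(C(=O)NO)cc3)ccn2)c(F)c1`) replaces the 4-fluorophenyl of compound 3 with 2-fluoro-4-methylphenyl, on an aromatic carbon next to the ring nitrogen: 2-fluoro-4-methylphenyl in place of 4-fluorophenyl on an aromatic carbon.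

Three measured steps change the group at this same place. Two of them, a 3.5-fold higher number from compound 1 to compound 2 (0.55 log units; beyond the scatter) and an at least 6.8-fold higher number from compound 1 to compound 3 (0.83 log units; beyond the scatter), leave the 2-hydroxyphenyl group, which compound 4 does not carry, so neither points to a comparable change here. The third, an at least 1.9-fold higher number from compound 2 to compound 3 (0.28 log units; that floor lies within the scatter), has a floor that does not separate its two compounds. For the measured compounds named here, no measured step goes from one ring of carbon only to another, and compound 3 remains the nearest measured neighbour of compound 4.

A small step is expected, an at least 1.2-fold lower number from compound 3 to compound 4 (0.09 log units; that floor lies within the scatter), tentatively toward a lower number. A reported limit rather than a number would also be unsurprising. The estimate for compound 4 is 8000 nM, with an expected range of 2500 nM to 20000 nM.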

Compound 4, half-maximal inhibitory concentration: 800 nM
For compound 4 the middle estimate is 10-fold (1.00 log units) above the measured one; the measured number lies below the stated range.
By their numbers in this assay, from the lowest: compounds 4 and 1 (each within the scatter of the next); then compound 2. At a limit, above all of these: compound 3.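

On an aromatic carbon next to the ring nitrogen, a ring of carbon only can give measurable activity in this assay: 2-fluoro-4-methylphenyl in place of 4-fluorophenyl gives an at least 12-fold lower number from compound 3 to compound 4 (1.09 log units; beyond the scatter), so the outcome at this position turns on the substituents of the ring and not just on whether the ring holds only carbon. The 2-hydroxyphenyl group of compound 1 is therefore not needed for activity in this range, as a 1.8-fold lower number from compound 1 to compound 4 (0.26 log units; within the scatter) leaves the two compounds unseparated, while the pyridin-3-yl group falls behind compound 4, with a 6.4-fold lower number from compound 2 to compound 4 (0.81 log units; beyond the scatter). The value of compound 3 is a limit and not a number, so the large step is a floor: the limit of > 10000 nM in this assay, at which 1 of the 4 values shown sits.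

As far as these compounds go, how much of that step belongs to the added methyl and how much to the changed place of the fluorine stays open, as does whether either group alone would be enough. Also open, from the compounds shown here alone, is whether a 2-aminophenyl group, or a phenyl ring carrying a methoxy group or a carboxylic acid, would hold activity at this position.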